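The source may report more compounds than this note shows. Statements on the series, on what has been measured and on what is new or still open speak of the compounds shown alone.

Measured in a functional assay on HeLa cells (Homo sapiens) for antiproliferative activity, read by MTT assay, with a stated time of 72 h (on this read-out lower numbers stand for stronger inhibition and higher numbers for weaker inhibition), so far:
- compound 1 `COc1ccc(N2C(=O)COc3ccc(-c4cnc(Cl)c(NS(=O)(=O)c5ccc(F)cc5)c4)cc32)cc1` gives 8320 nM as a number
- compound 2 `O=C1COc2ccc(-c3cnc(Cl)c(NS(=O)(=O)c4ccc(F)cc4)c3)cc2N1c1ccc(F)cc1` gives > 40000 nM as a limit of the assay

Compound 2 stands at the limit of > 40000 nM in this assay, at which 1 of the 2 values shown sits, and has no number of its own. Compound 3 `O=C1COc2ccc(-c3cnc(Cl)c(NS(=O)(=O)c4ccc(F)cc4)c3)cc2N1c1ccc(Cl)cc1` differs from compound 2 by chloro in place of fluoro on an aromatic carbon and reads as 4-fluorophenyl to 4-chlorophenyl, chloro in place of fluoro on an aromatic carbon.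

Going by the values given here, one measured step bears on this change: an at least 4.8-fold higher number from compound 1 to compound 2 (0.68 log units; beyond the scatter) for fluoro in place of methoxy on the same aromatic carbon. Among the compounds with values here, that step shows this assay responding to a swap of this group, but no measured compound carries chloro. Within the data shown here, compound 1 at 8320 nM is the only compound with a number, so that number marks the low side of what is expected here. A small move to a lower number is expected, possibly none beyond the scatter. The expected size is an at least 1.3-fold lower number from compound 2 to compound 3 (0.12 log units; that floor lies within the scatter) and the result may equally stay at the limit. For compound 3 the estimated value is 30000 nM with an expected range from 10000 nM to 70000 nM for now.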

Compound 3, half-maximal inhibitory concentration: > 40000 nM
Compound 3 was reported as a limit; the forecaster's own chance of this, stated with the estimate: 50%; middle value at least 1.3-fold (0.12 log units) away from the limit.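

this assay now has a second halogen to set against methoxy, and the outcome matches the first: the step reads an at least 4.8-fold higher number from compound 1 to compound 3 (0.68 log units; beyond the scatter). On this aromatic carbon, para to a large group, chloro thus joins fluoro in giving a weaker read-out than methoxy, so the earlier loss is not confined to fluoro. The step between the two halogen compounds cannot be read, and no order between fluoro and chloro can be given, since both compounds end at the same limit of the assay and neither has a number of its own: the limit of > 40000 nM in this assay, at which 2 of the 3 values shown sit.

Among the three compounds, only compound 1 has a number, 8320 nM, so the series still offers no measured difference between any two groups other than against methoxy, and the true distance of the halogen compounds from it stays unknown. As far as these compounds go, it remains open whether an ethoxy group, a hydroxyl or a dimethylamino group on this carbon would give a number at all, and whether that number would fall on the stronger or the weaker side of compound 1.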